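Moving the Fluorine on the Phenyl Ring

This account rests on a few compounds, and the source may have more. Where it says the series, first, only, none or still open, it means among the compounds named here.

This account follows a small series tested in a functional assay on CFPAC-1 cells (Homo sapiens) for antiproliferative activity, read by MTT assay, with a stated time of 72 h; on this read-out higher numbers stand for weaker inhibition and lower numbers for stronger inhibition. Among the measured compounds shown here, compound 1 `CCCCCCc1cc2cn(Cc3cn(-c4ccccc4F)nn3)c(=O)nc2o1` is the first member. In this assay compound 1 reaches only a limit, > 100000 nM. Compound 2 `O=c1nc2oc(CCCCl)cc2cn1Cc1cn(-c2ccccc2F)nn1` differs from compound 1 by a single change, chloro in place of propyl on a saturated chain carbon, three bonds along the chain from an aromatic carbon; in this assay compound 2 gives 81800 nM. The step from compound 1 to compound 2 is an at least 1.2-fold lower number from compound 1 to compound 2 (0.08 log units; that floor lies within the scatter), resting on (the limit of > 100000 nM in this assay, at which 1 of the 2 values shown sits). Compound 2 thus stands as the only number shown, the other value being a limit.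

Compound 3 `O=c1nc2oc(CCCCl)cc2cn1Cc1cn(-c2ccc(F)cc2)nn1` is not yet measured. It differs from compound 2 in 4-fluorophenyl in place of 2-fluorophenyl on an aromatic nitrogen. For the measured compounds named here, no measured step touches the fluorophenyl group, so nothing here points in either direction, and the one measured step lies near the scatter floor. The expected step is therefore a 1.0-fold lower number from compound 2 to compound 3 (0.01 log units; within the scatter), within the usual scatter. The estimate for compound 3 in this assay is 80000 nM, with a range from 30000 nM to 250000 nM.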

Compound 3, half-maximal inhibitory concentration: 6490 nM
Compound 3: middle estimate off by 12-fold (1.09 log units), on the high side; the measured number lies below the stated range.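

Among the compounds shown here, the change from 2-fluorophenyl to 4-fluorophenyl on the aromatic nitrogen gives a 13-fold lower number from compound 2 to compound 3 (1.10 log units; beyond the scatter) in this assay, and it is the first step that can be read as a clear change. The earlier step, made on the saturated chain, rested on a limit and had a floor within the scatter, whereas this one falls on the fluorophenyl group, showing that activity in this series responds to a change at this place. The two groups have the same atoms and the same counts, so only the place of the fluorine on the phenyl ring differs, but nothing given here explains why that shift matters.

From the compounds shown here alone, whether the gain is special to 4-fluorophenyl remains open, since 3-fluorophenyl, plain phenyl, and a phenyl ring carrying chloro or methoxy at the same place would each test it further. Going by these compounds, it is also open whether 4-fluorophenyl would bring a similar step when paired with the chain of compound 1 rather than the chloro-ended chain of compound 3.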